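Swapping isopropyl for hydroxymethyl in a series stuck at a limit

This account rests on a few compounds, and the source may have more. Where it says the series, first, only, none or still open, it means among the compounds named here.

Of the compounds shown here, three have been read in an ADME assay on KB cells (Homo sapiens) for cytotoxicity, with a stated time of 48 h (on this read-out lower numbers stand for stronger inhibition and higher numbers for weaker inhibition), and none of them yields a number. Compound 1 (`C=C1[C@H](C)CCC[C@]1(C)CC/C(C)=C/CC1=C(O)C(=O)C=C(N[C@H](CO)C(=O)O)C1=O`) gives > 10 ug/mL, which is a limit of the assay. Compound 2 (`CC1=CCC[C@](C)(CC/C(C)=C/CC2=C(O)C(=O)C=C(N[C@@H](CO)C(=O)O)C2=O)[C@@H]1C`) gives > 10 ug/mL, again a limit. Compound 3 (`CC1=CCC[C@](C)(CC/C(C)=C/CC2=C(O)C(=O)C=C(N[C@@H](C(=O)O)C(C)C)C2=O)[C@@H]1C`) gives > 10 ug/mL, also a limit, so its standing is known only as far as that limit tells.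

The next structure is compound 4 (`CC1=CCC[C@](C)(CC/C(C)=C/CC2=C(O)C(=O)C=C(N[C@H](CO)C(=O)O)C2=O)[C@@H]1C`). The change is hydroxymethyl in place of isopropyl on a saturated chain carbon bound to an amine nitrogen and a carbonyl carbon.

Going by the values given here, the one measured step that bears on this swaps the same two groups the other way, a step that the two limits leave unreadable from compound 2 to compound 3. Its size cannot be read because of the limit of > 10 ug/mL in this assay, at which 3 of the 3 values shown sit. With no number behind that step, the data argue for no direction. What is expected in this assay is therefore no clear shift either way, an estimated step that the limit leaves unreadable from compound 3 to compound 4. For compound 4 the estimated value is 20 ug/mL, with an expected range of 10 ug/mL to 50 ug/mL, and the assay may well report only a limit again.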

Compound 4, half-maximal inhibitory concentration: > 10 ug/mL
Compound 4 ended at the assay's limit; the forecaster's own chance of this, stated with the estimate: 85%; the middle value does not contradict the limit.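

No new step can be read among compound 1, compound 2, compound 3 and compound 4, since all of them end at a limit of the assay rather than a number: the limit of > 10 ug/mL in this assay, at which 4 of the 4 values shown sit.

The compounds shown leave open whether the swap between isopropyl and hydroxymethyl, or the configuration as drawn, shifts the read-out in this assay at all.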